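Compound 4: 2-Hydroxycyclopentyl in Place of 2-Hydroxycyclohexyl

This account rests on a few compounds, and the source may have more. Where it says the series, first, only, none or still open, it means among the compounds named here.

Three compounds share a core and differ only in where the bromine sits on the phenyl ring. In an assay on membranes from cerebrum (strain Sprague-Dawley) for displacement of a labelled ligand from Sigma non-opioid intracellular receptor 1 (Rattus norvegicus), read by scintillation counting, with a stated time of 90 min (on this read-out higher numbers stand for weaker inhibition and lower numbers for stronger inhibition), compound 1 `O[C@H]1CCCC[C@@H]1N1CCN(CCCc2ccccc2Br)CC1` gives 19.4 nM, compound 2 `O[C@H]1CCCC[C@@H]1N1CCN(CCCc2cccc(Br)c2)CC1` gives 7.7 nM, and compound 3 `O[C@H]1CCCC[C@@H]1N1CCN(CCCc2ccc(Br)cc2)CC1` gives 4.4 nM. Compound 1 thus has the highest number of the three: the step of a 2.5-fold lower number from compound 1 to compound 2 (0.40 log units; beyond the scatter) and the step of a 4.4-fold lower number from compound 1 to compound 3 (0.64 log units; beyond the scatter) both lie beyond the scatter, whereas the step of a 1.8-fold lower number from compound 2 to compound 3 (0.24 log units; within the scatter) does not.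

Compound 4 `O[C@H]1CCC[C@@H]1N1CCN(CCCc2ccccc2Br)CC1` keeps the 2-bromophenyl of compound 1 and changes the other end of the molecule: 2-hydroxycyclopentyl in place of 2-hydroxycyclohexyl on an amine nitrogen in a ring. Going by the values given here, none of the measured steps touches this part of the structure; all three concern the position of the bromine, so they give no direct guide to a change on the amine nitrogen in a ring. With the bromine held fixed, there is no measured reason to expect a shift beyond the scatter in this assay. The step of a 1.1-fold higher number from compound 1 to compound 4 (0.05 log units; within the scatter) is therefore expected to stay within the scatter. Compound 4 is estimated at 22 nM, with a range from 8 nM to 60 nM.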

Compound 4, inhibition constant: 37.1 nM
The estimate for compound 4 lay 1.7-fold (0.23 log units) below the measured number; the measured number falls inside the stated range.
By their numbers in this assay, from the lowest: compounds 3 and 2 (each within the scatter of the next); then compounds 1 and 4 (each within the scatter of the next).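

In this assay, going by these compounds alone, the change at the amine nitrogen in a ring gives the first reading for this end of the molecule: a 1.9-fold higher number from compound 1 to compound 4 (0.28 log units; within the scatter). Replacing the six-membered carbon ring of 2-hydroxycyclohexyl with the five-membered carbon ring of 2-hydroxycyclopentyl therefore gives no difference that can be told from the scatter, at least with the 2-bromophenyl in place, whereas moving the bromine gave a 4.4-fold lower number from compound 1 to compound 3 (0.64 log units; beyond the scatter), a step beyond it. No measurement shown here offers an explanation for how this ring change behaves.

Going by these compounds, since 2-hydroxycyclopentyl appears here only with the 2-bromophenyl, it remains open whether the same ring change would also stay within the scatter on the 3-bromophenyl of compound 2 or the 4-bromophenyl of compound 3. Also open, on these data alone, is how the assay would read with other groups on this nitrogen, such as 2-aminocyclohexyl, which carries an amine where these rings carry the hydroxyl, or an open-chain 2-hydroxyethyl.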